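The compounds below may be only part of what the source reports. "The series", "measured", "known", "first", "only" and "open" are said of these compounds alone.

Compound 1 `O=C(/C=C/c1cccnc1)NCCCCCCc1cccc(S(=O)(=O)Nc2ccccc2)c1`: 0.63 nM
Compound 2 `O=C(/C=C/c1cccnc1)NCCCCCCc1cccc(S(=O)(=O)Nc2ccc(C(F)(F)F)cc2)c1`: 67.8 nM

Both values come from a functional assay on MCF7 cells (Homo sapiens) for inhibition, read by CCK-8 assay, with a stated time of 72 h; a higher number here means a weaker inhibitor, a lower number a stronger inhibitor. Compound 2 has the higher of the two numbers, 67.8 nM, which makes it the weaker inhibitor of the pair.

The next compound, compound 3 `O=C(/C=C/c1cccnc1)NCCCCCCc1cccc(S(=O)(=O)Nc2ccc(Oc3ccccc3)cc2)c1`, carries phenoxy in place of trifluoromethyl on an aromatic carbon. Among the measured compounds shown here, only one measured step bears on this change: a 110-fold higher number from compound 1 to compound 2 (2.03 log units; beyond the scatter). That step is large and lies beyond the scatter, and it involves the same aromatic carbon, so what sits there clearly matters in this assay. However, it compares a group only with hydrogen. For the measured compounds named here, no measured compound carries phenoxy, and a single step cannot show whether other groups at this place behave as trifluoromethyl does.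

The expectation is therefore that compound 3 stays near compound 2, perhaps slightly lower, with no step beyond the scatter. The expected step is a 1.7-fold lower number from compound 2 to compound 3 (0.23 log units; within the scatter). The estimate for compound 3 is 40 nM, with an expected range from 4 nM to 300 nM.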

Compound 3, half-maximal inhibitory concentration: 3.84 nM
Beside the measured number, compound 3's estimate is 10-fold (1.02 log units) above it, and the stated range ends above it.
By their numbers in this assay, from the lowest: compound 1; then compound 3; then compound 2.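

In this assay, the step of an 18-fold lower number from compound 2 to compound 3 (1.25 log units; beyond the scatter) shows that the large loss seen with trifluoromethyl is not shared by every group at this aromatic carbon: the identity of the group matters, not merely the replacement of hydrogen. Phenoxy, which enters with more heavy atoms than trifluoromethyl and brings a six-membered aromatic ring of its own, still does not match hydrogen, as the step of a 6.1-fold higher number from compound 1 to compound 3 (0.78 log units; beyond the scatter) shows, although this step is modest where the step to trifluoromethyl is large. Nothing measured here accounts for the difference between these groups at this place.

From the compounds shown here alone, with only hydrogen, trifluoromethyl and phenoxy at this carbon, it remains open whether the oxygen of phenoxy, its ring or its total number of heavy atoms separates it from trifluoromethyl; a methoxy group would keep the oxygen without the ring, and a phenyl group would keep the ring without the oxygen. It also remains open whether the same order of these three compounds would hold outside this assay, the only read-out shown.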